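This account rests on a few compounds, and the source may have more. Where it says the series, first, only, none or still open, it means among the compounds named here.

Measured compounds:
compound 1 `N#C/N=C(/NCCCc1c[nH]cn1)NCCSc1ccccc1` — < 5
compound 2 `N#C/N=C(\NCCCCc1ccccc1)NCCCCc1c[nH]cn1` — 5.03
compound 3 `N#C/N=C(/NCCCCc1c[nH]cn1)NCCC(c1ccccc1)c1ccccc1` — 5

Compound 2 stands among the two numbers given in an in vitro functional assay on Sf9 cells for antagonist activity at histamine H2 receptor (Homo sapiens) (a higher number here means a more potent compound, by a factor of ten per unit of this negative logarithm, a lower number a less potent compound), where compound 2 gives 5.03. Compound 3 gives 5 in this assay, a value that lies within the usual scatter of that of compound 2, so the two cannot be told apart. For compound 1 this assay reports only a limit, < 5, not a number (the limit of < 5 in this assay, at which 1 of the 3 values shown sits).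

Compound 4 `CCN/C(=N\C#N)NCCCCc1c[nH]cn1` has not yet been measured. It differs from compound 2 in one place: hydrogen in place of phenethyl on a saturated chain carbon, two bonds along the chain from an amine nitrogen. A large group leaves and only a hydrogen enters, so the side chain becomes much shorter. Going by the values given here, no measured pair here shows the effect of such a change, so the size of the step can only be guessed; with compound 2 sitting close to the limit of this assay, a step downward beyond the scatter seems the more likely outcome, and compound 4 may well fall to the limit.

Compound 4 is expected to give about 4.7 in this assay, within a range from 4.2 to 5.3. This expectation means a step of a number 0.33 log units lower from compound 2 to compound 4 (beyond the scatter).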

Compound 4, negative logarithm of the antagonist equilibrium constant: < 5
Compound 4 gave a limit, no number (the forecaster's own chance of this, stated with the estimate: 55%); the middle value is on the limit's open side.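

In this assay compound 4 gives < 5, which is a limit of the assay and not a number. Putting hydrogen in place of phenethyl on this saturated chain carbon, two bonds along the chain from an amine nitrogen, gives a step of a number at least 0.03 log units lower from compound 2 to compound 4 (that floor lies within the scatter), so this change brings no gain that can be seen, but a real loss cannot be confirmed either. Compound 4 therefore joins the compounds that can be placed only by a limit: the limit of < 5 in this assay, at which 2 of the 4 values shown sit.

As far as these compounds go, how much potency the phenethyl group actually contributes remains open, as only a floor for the step can be read. Also open, from the compounds shown here alone, is how a benzyl group, a longer chain or a chain ending in an amine or a carboxylic acid would behave at this place.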